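From Chloromethyl to Furan-2-yl on the Carbonyl

The compounds below may be only part of what the source reports. "The series", "measured", "known", "first", "only" and "open" are said of these compounds alone.

In a functional assay on HepG2 cells (Homo sapiens) for cytotoxicity, read by MTT assay (on this read-out lower numbers stand for stronger inhibition and higher numbers for weaker inhibition), compound 1 `COc1ccc(/C=C/C(=O)c2ccc(OC)c3c2OC(C)(C)C=C3)cc1OCC=C(C)C` gives > 10000 nM, which is a limit of the assay and not a number. Among the compounds with values here, compound 2 `COc1ccc(/C=C/C(=O)c2ccc(OC)c3c2OC(C)(C)C=C3)cc1OC(=O)CCl` gives 120 nM, the only true number so far. Within the data shown here, the one measured step, an at least 83-fold lower number from compound 1 to compound 2 (1.92 log units; beyond the scatter), is large and swaps the whole group on the oxygen. Its size rests on (the limit of > 10000 nM in this assay, at which 1 of the 2 values shown sits). Compound 3 `COc1ccc(/C=C/C(=O)c2ccc(OC)c3c2OC(C)(C)C=C3)cc1OC(=O)c1ccco1` keeps the carbonyl but changes what it carries: furan-2-yl in place of chloromethyl on a carbonyl carbon. Among the measured compounds shown here, no measured step covers this exchange, so a moderate to large move towards a higher number is expected from compound 2 at 120 nM. The expected step is a 13-fold higher number from compound 2 to compound 3 (1.10 log units; beyond the scatter). For compound 3 the estimated value is 1500 nM, within a range of 200 nM to 10000 nM.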

Compound 3, half-maximal inhibitory concentration: 370 nM
Compound 3: the middle estimate sits 4.1-fold (0.61 log units) above what was measured; measured number inside the range.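

In this assay, furan-2-yl in place of chloromethyl on the carbonyl carbon gives a 3.1-fold higher number from compound 2 to compound 3 (0.49 log units; beyond the scatter), so the number does shift with what the carbonyl carries, but only modestly. Compared with 3-methylbut-2-en-1-yl on the oxygen, (furan-2-yl)carbonyl still gives an at least 27-fold lower number from compound 1 to compound 3 (1.43 log units; beyond the scatter), so the large drop now appears with two different carbonyl groups and does not depend on chloromethyl alone. The size of this step is not fixed: the limit of > 10000 nM in this assay, at which 1 of the 3 values shown sits.

Going by these compounds, whether a carbonyl carrying a simple methyl or an amine would sit closer to compound 2 or to compound 3 remains open.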